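Trimming the sugar ring down to a short diol chain

The source may hold more compounds than are shown below. What is called first, only, known or untested is meant among the compounds shown, and "the series" means these compounds.

In a toxicity assay on HEK-293T cells (Homo sapiens) for cytotoxicity, read by MTT assay, with a stated time of 72 h (a lower number here means a stronger inhibitor, a higher number a weaker inhibitor), compound 1, whose structure is `O=C1c2c[n+]([O-])c3ccccc3c2C(=O)c2c1c1ccccc1n2CCCCn1ccnc1`, gives 280 nM. Compound 2, with structure `O=C1c2c[n+]([O-])c3ccccc3c2C(=O)c2c1c1ccccc1n2Cc1cn([C@@H]2C[C@H](O)[C@@H](CO)O2)nn1`, gives 820 nM in this assay, the higher of the two numbers, so it is the weaker inhibitor of the pair, and the gap to compound 1 is beyond the usual scatter. Compound 3, `O=C1c2c[n+]([O-])c3ccccc3c2C(=O)c2c1c1ccccc1n2Cc1cn(C[C@@H](O)CO)nn1`, has not been measured. It differs from compound 2 in one place: 2,3-dihydroxypropyl in place of 4-hydroxy-5-(hydroxymethyl)oxolan-2-yl on an aromatic nitrogen. The ring that leaves and the chain that enters both carry two hydroxyl groups, and the exchange keeps the rest of the shared core untouched. Among the measured compounds shown here, no measured pair here tracks this exact change, so a conservative reading is that the step from compound 2 to compound 3 is expected to be small, a 1.2-fold lower number from compound 2 to compound 3 (0.07 log units; within the scatter), and not clearly beyond the scatter. Compound 3 is therefore estimated at 700 nM, with a range from 250 nM to 2000 nM.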

Compound 3, half-maximal inhibitory concentration: 2030 nM
Compound 3: the middle estimate sits 2.9-fold (0.46 log units) below what was measured; measured number above the stated range.
By their numbers in this assay, from the lowest: compound 1; then compound 2; then compound 3.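

Swapping 4-hydroxy-5-(hydroxymethyl)oxolan-2-yl for 2,3-dihydroxypropyl on the aromatic nitrogen gives a 2.5-fold higher number from compound 2 to compound 3 (0.39 log units; beyond the scatter) in this assay, so this position responds to the change even though both groups carry the same count of hydrogen-bond donors. Compound 3 is also the weakest inhibitor of the three, with a 7.3-fold higher number from compound 1 to compound 3 (0.86 log units; beyond the scatter) when 1-(2,3-dihydroxypropyl)-1H-1,2,3-triazol-4-yl stands in place of 3-(1H-imidazol-1-yl)propyl. Nothing available explains why the number rises in either step.

With only these compounds, the ring cannot be separated from the extra atoms that leave with it. Also open, on these data alone, is how a simple oxolan-2-yl ring without hydroxyl groups, a longer chain ending in an amine, or a carboxylic acid would behave on this nitrogen.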